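The source may report more compounds than this note shows. Statements on the series, on what has been measured and on what is new or still open speak of the compounds shown alone.

Working notes on the series. In a functional assay on RS4-11 cells (Homo sapiens) for inhibition, read by CCK-8 assay, with a stated time of 48 h (on this read-out lower numbers stand for stronger inhibition and higher numbers for weaker inhibition), compound 1 `O=[N+]([O-])c1ccc(NC(=S)NCCNS(=O)(=O)c2ccc(-c3ccccc3OCc3ccccc3)s2)cc1` gives 11300 nM. Compound 2 `O=C(NCCNS(=O)(=O)c1ccc(-c2ccccc2OCc2ccccc2)s1)Nc1cc(Cl)cc(Cl)c1` gives only a limit of the assay, > 20000 nM, as recorded in the limit of > 20000 nM in this assay, at which 1 of the 3 values shown sits. Compound 3 `O=C(NCCNS(=O)(=O)c1ccc(-c2ccccc2O[C@H]2CC[C@H](O)CC2)s1)Nc1cc(Cl)cc(Cl)c1` gives 14100 nM. The change from compound 2 to compound 1 is a group of 12 heavy atoms (7 carbon, 2 nitrogen, 2 oxygen, 1 sulfur; one six-membered aromatic ring of carbon only) in place of a group of 11 heavy atoms (7 carbon, 1 nitrogen, 1 oxygen, 2 chlorine; one six-membered aromatic ring of carbon only), on an amine nitrogen, and it brought an at least 1.7-fold lower number from compound 2 to compound 1 (0.24 log units; that floor lies within the scatter). The two cores differ by 4-hydroxycyclohexyl in place of benzyl on an oxygen on an aromatic ring, with an at least 1.4-fold lower number from compound 2 to compound 3 (0.15 log units; that floor lies within the scatter). Compound 4 `O=[N+]([O-])c1ccc(NC(=S)NCCNS(=O)(=O)c2ccc(-c3ccccc3O[C@H]3CC[C@H](O)CC3)s2)cc1` carries the same change on the core of compound 3: a group of 12 heavy atoms (7 carbon, 2 nitrogen, 2 oxygen, 1 sulfur; one six-membered aromatic ring of carbon only) in place of a group of 11 heavy atoms (7 carbon, 1 nitrogen, 1 oxygen, 2 chlorine; one six-membered aromatic ring of carbon only), on an amine nitrogen, at the same place as before. The step is expected to resemble the earlier one, with compound 4 estimated to reach 9000 nM (range 4000 nM to 20000 nM), because compound 1 gives 11300 nM on the other core. That rests on the expected step of a 1.6-fold lower number from compound 3 to compound 4 (0.19 log units; within the scatter).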

Compound 4, half-maximal inhibitory concentration: 1500 nM
Compound 4: middle estimate off by 6.0-fold (0.78 log units), on the high side, outside the stated range (below it).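

In this assay, the group of compound 4 in place of (3,5-dichlorophenyl)carbamoyl on the amine nitrogen brings a 9.4-fold lower number from compound 3 to compound 4 (0.97 log units; beyond the scatter), and 4-hydroxycyclohexyl in place of benzyl on the oxygen brings a 7.5-fold lower number from compound 1 to compound 4 (0.88 log units; beyond the scatter). Whether the first change carries the same size of step from one core to the other stays unsettled: the same change on two cores in this assay, an at least 1.7-fold lower number (0.24 log units; that floor lies within the scatter) from compound 2 to compound 1 and a 9.4-fold lower number (0.97 log units; beyond the scatter) from compound 3 to compound 4; the limit leaves it open whether they differ The second change stands no differently: the same change on two cores in this assay, an at least 1.4-fold lower number (0.15 log units; that floor lies within the scatter) from compound 2 to compound 3 and a 7.5-fold lower number (0.88 log units; beyond the scatter) from compound 1 to compound 4; the limit leaves it open whether they differ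

The compounds shown do not separate the sulfur from the nitro group of the entering group, so it stays open which of the two goes with the step. Also open, on these data alone, is how an amine or a carboxylic acid in place of the hydroxyl on the cyclohexyl ring would read in this assay.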